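Trading a vinyl for a 2-oxopropyl on the ether chain

This account rests on a few compounds, and the source may have more. Where it says the series, first, only, none or still open, it means among the compounds named here.

Three compounds share one core and differ only in the chain on the aromatic ether oxygen. In an assay on isolated protein for inhibition of leukotriene B4 receptor 1 (Homo sapiens), tested at 10 uM (a lower number here means less inhibition, a higher number more inhibition at the concentration tested (going by the name of the read-out)), compound 3 `C=CCCCCOc1cc(O)c(C(C)=O)cc1CC=C` gives 73%, the highest of the three numbers. Compound 1 `C=CCc1cc(C(C)=O)c(O)cc1OCCCCCCCCCCC#N` gives 50% in this assay, and compound 2 `C=CCc1cc(C(C)=O)c(O)cc1OCCCC` gives 32%. The step of a number 41 percentage points higher from compound 2 to compound 3 (beyond the scatter) is the largest seen, and a number 23 percentage points higher from compound 1 to compound 3 (beyond the scatter) also lies beyond the scatter, so compound 3 stands clearly above both neighbours.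

Compound 4 `C=CCc1cc(C(C)=O)c(O)cc1OCCCCCC(C)=O` differs from compound 3 by 2-oxopropyl in place of vinyl on a saturated chain carbon, four bonds along the chain from an oxygen on an aromatic ring. Among the measured compounds shown here, no measured step makes exactly this exchange. The step from compound 1 to compound 3 bears on it most closely, as there a chain that carries a hydrogen-bond acceptor gave way to the vinyl with a number 23 percentage points higher from compound 1 to compound 3 (beyond the scatter); the step from compound 2 to compound 3 shows that a bare chain end is weaker still, with a number 41 percentage points higher from compound 2 to compound 3 (beyond the scatter). Compound 4 again places a hydrogen-bond acceptor on the chain, though on a shorter chain than in compound 1, so a modest fall relative to compound 3 is expected rather than a return to the level of compound 2. The expected step is a number 18 percentage points lower from compound 3 to compound 4 (beyond the scatter). For compound 4 the estimate in this assay is 55%, within a range of 35% to 75%.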

Compound 4, a percentage reported as inhibition, at one concentration (the size of the read-out at that concentration, not a potency): 98%
The estimate for compound 4 lay 43 percentage points below the measured number; the whole stated range lies below it.
By their numbers in this assay, from the lowest: compound 2; then compound 1; then compound 3; then compound 4.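

In this assay the 2-oxopropyl group at this place, on a saturated chain carbon four bonds along the chain from an oxygen on an aromatic ring, outdoes the vinyl with a number 25 percentage points higher from compound 3 to compound 4 (beyond the scatter) and so shows that the vinyl end of compound 3 did not mark the upper limit for this chain. It also stands well clear of the bare chain end with a number 66 percentage points higher from compound 2 to compound 4 (beyond the scatter) and of the long nitrile chain with a number 48 percentage points higher from compound 1 to compound 4 (beyond the scatter), yet a hydrogen-bond acceptor on the chain does not by itself set the level: compound 1 also carries one and lies below compound 3, which has none. Nothing available accounts for the rise.

Compound 4 gives 98% at a single concentration, which leaves little room above it and leaves open how far it truly separates from compound 3 in potency. Going by these compounds, it also remains open whether the carbonyl itself matters, and how a hydroxyl, a carboxylic acid or an amine at the chain end, or a longer chain carrying the same acetyl, would compare.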